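A few compounds are considered here, and "the series" means these few. Any claim that something is new, unique, unknown or untested is made for them only; others in the source may bear on it.

Compound 1 `COc1cccc2c1c(C(=O)/C=C(\O)C(=O)O)cn2Cc1cc(F)ccc1F` and compound 3 `COc1cccc2c1c(C(=O)/C=C(\O)C(=O)O)cn2Cc1ccccc1F` share one core and differ in a single place: hydrogen in place of fluoro on an aromatic carbon. In an ADME assay on MT4 cells (Homo sapiens) for cytotoxicity, read by MTT assay (on this read-out higher numbers stand for lower toxicity in this test and lower numbers for higher toxicity in this test), compound 1 gives 46200 nM, and compound 3 gives 70500 nM, so that the change brings a 1.5-fold higher number from compound 1 to compound 3 (0.18 log units; within the scatter). Compound 2 `CCOC(=O)/C(O)=C/C(=O)c1cn(Cc2cc(F)cc(F)c2)c2cccc(OC)c12` carries an ethyl ester where compound 1 carries the free acid, and a differently substituted benzyl group; the difference between the two cores is not broken down here. In this assay compound 2 gives 34700 nM.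

Compound 4 `CCOC(=O)/C(O)=C/C(=O)c1cn(Cc2cccc(F)c2)c2cccc(OC)c12` has not yet been tested in this assay. It differs from compound 2 in one place: hydrogen in place of fluoro on an aromatic carbon. Among the compounds with values here, this is the same kind of change as the one from compound 1 to compound 3, but not the same change: in compound 1 the departing fluoro sits on an aromatic carbon that is meta to a large group and para to a fluoro group, whereas in compound 2 it sits on a carbon that is meta to a fluoro group and meta to a large group.

Because the step of a 1.5-fold higher number from compound 1 to compound 3 (0.18 log units; within the scatter) stayed within the scatter, the step from compound 2 to compound 4 is expected to be similarly modest, a 1.3-fold higher number from compound 2 to compound 4 (0.11 log units; within the scatter). Compound 4 is estimated at 45000 nM in this assay, with an expected range from 25000 nM to 90000 nM.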

Compound 4, half-maximal cytotoxic concentration: 63200 nM
For compound 4 the middle estimate is 1.4-fold (0.15 log units) below the measured one; low and high end bracket the measured number.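

Hydrogen in place of fluoro, here the change from 3,5-difluorobenzyl to 3-fluorobenzyl, gives a 1.8-fold higher number from compound 2 to compound 4 (0.26 log units; within the scatter) in this assay. Set beside the same kind of change on the core of compound 1, the result on this second core agrees with the earlier one: the same change on two cores in this assay, a 1.5-fold higher number (0.18 log units; within the scatter) from compound 1 to compound 3 and a 1.8-fold higher number (0.26 log units; within the scatter) from compound 2 to compound 4, 1.2-fold (0.08 log units) apart, within the scatter of two such steps. This shows that, across these two pairs, the change carried from one core to the other without a readable difference in size, but since each step stays within the scatter, it does not establish that the change has any real effect on this read-out, and two pairs, with the fluoro leaving a different place in each, cannot establish a rule for the whole series.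

The compounds shown leave open what other groups would do in the place of this fluoro on the benzyl group, such as a chlorine, a methyl group or an amine, since only fluoro and hydrogen appear there. They also leave open how the ethyl ester compares with the free carboxylic acid on an otherwise identical benzyl group, and whether an amide or a longer ester chain in that place would give a different number in this assay.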